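A few compounds are considered here, and "the series" means these few. Any claim that something is new, unique, unknown or untested is made for them only; others in the source may bear on it.

Measured compounds in a functional assay on A549 cells (Homo sapiens) for cytotoxicity, read by MTT assay, with a stated time of 24 h, tested at 60 uM; a higher number here means a weaker effect of the compound at the concentration tested, a lower number a stronger effect:
- compound 1, `CCCCCCCCOC(=O)CCC(=O)N1CCN(CCCOc2cc3c(Nc4ccc(F)c(Cl)c4)ncnc3cc2OC)CC1`, 26%
- compound 2, `CCCCCCCCCCCOC(=O)CCC(=O)N1CCN(CCCOc2cc3c(Nc4ccc(F)c(Cl)c4)ncnc3cc2OC)CC1`, 3.9%
- compound 3, `CCCCCCCCCCCCCCCOC(=O)CCC(=O)N1CCN(CCCOc2cc3c(Nc4ccc(F)c(Cl)c4)ncnc3cc2OC)CC1`, 81.6%

Compound 3 gives the highest number of the three in this assay, with compound 1 nearest and compound 2 furthest; both of its steps to the others are beyond the scatter. The steps along the chain do not run in one direction: a number 22.1 percentage points lower from compound 1 to compound 2 (beyond the scatter), then a number 55.6 percentage points higher from compound 1 to compound 3 (beyond the scatter) and a number 77.7 percentage points higher from compound 2 to compound 3 (beyond the scatter). Lengthening from compound 1 to compound 2 strengthened the effect, while the further lengthening to compound 3 nearly abolished it.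

Compound 4, `CCCCCCCCCCCCCCCCCCCCOC(=O)CCC(=O)N1CCN(CCCOc2cc3c(Nc4ccc(F)c(Cl)c4)ncnc3cc2OC)CC1`, continues the same lengthening: pentyl in place of hydrogen on a saturated chain carbon, ten or more bonds along the chain from an oxygen next to a carbonyl group. The step from compound 2 to compound 3 is the one most alike in kind and place and was large toward weaker effect; the step from compound 1 to compound 2 points the other way but sits closer to the carbonyl side. Taken together, compound 4 is expected to stay near or above compound 3, a step of a number 6.4 percentage points higher from compound 3 to compound 4 (within the scatter) that is likely within the scatter, since little room remains upward. The estimate for compound 4 in this assay is 88%, range 60% to 100%.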

Compound 4, a percentage reported as activity, at one concentration (the size of the read-out at that concentration, not a potency): 86.9%
Compound 4: middle estimate off by 1.1 percentage points, on the high side, within the range that was stated.
By their numbers in this assay, from the lowest: compound 2; then compound 1; then compounds 3 and 4 (each within the scatter of the next).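

In this assay the further pentyl at this place on the chain gives a number 5.3 percentage points higher from compound 3 to compound 4 (within the scatter) and so adds no measurable change: the weak effect reached with compound 3 persists in compound 4, and the loss of effect does not reverse with this lengthening. The wider comparisons, a number 83 percentage points higher from compound 2 to compound 4 (beyond the scatter) and a number 60.9 percentage points higher from compound 1 to compound 4 (beyond the scatter) show that compound 4 stays well apart from both shorter esters, and the series therefore reads as a turn at compound 2 followed by a flat stretch across compound 3 and compound 4. No measurement at hand accounts for this turn or for the flat stretch.

Where between the chains of compound 2 and compound 3 the effect falls away remains open. Also open, on these data alone, is how an amine or a carboxylic acid carried on the chain would compare with these plain alkyl esters.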